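Compound 1 loses a methyl group: working notes

The source may report more compounds than this note shows. Statements on the series, on what has been measured and on what is new or still open speak of the compounds shown alone.

Within the data shown here, in a toxicity assay on MT4 cells (Homo sapiens) for cytotoxicity, read by MTT assay (on this read-out higher numbers stand for lower toxicity in this test and lower numbers for higher toxicity in this test), compound 1 (`Cc1cc(-c2cccc(F)c2)cc(C)c1Oc1cc(N)nc(Nc2ccc(C#N)cc2)n1`) gives 24700 nM, the highest of the two numbers so far. Among the measured compounds shown here, its only measured neighbour, compound 2 (`Cc1cc(-c2ccc(C#N)c(F)c2)cc(C)c1Oc1cc(N)nc(Nc2ccc(C#N)cc2)n1`), gives 5000 nM. That single measured step, a 4.9-fold lower number from compound 1 to compound 2 (0.69 log units; beyond the scatter), comes with cyano in place of hydrogen on an aromatic carbon.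

Compound 3 (`Cc1cc(-c2cccc(F)c2)ccc1Oc1cc(N)nc(Nc2ccc(C#N)cc2)n1`) departs from compound 1 by hydrogen in place of methyl on an aromatic carbon. In words, this is hydrogen in place of methyl on an aromatic carbon, ortho to a large group and meta to a 3-fluorophenyl group.

For the measured compounds named here, no measured step replaces a methyl, so the evidence is indirect. The step of a 4.9-fold lower number from compound 1 to compound 2 (0.69 log units; beyond the scatter) serves only as a rough gauge of how far one small change has moved these numbers. On that basis, no shift beyond the scatter is expected in this assay, with a slight lean towards a lower number. The expected step is a 1.5-fold lower number from compound 1 to compound 3 (0.16 log units; within the scatter). For compound 3 the estimated value is 17000 nM (expected range 6000 nM to 40000 nM).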

Compound 3, half-maximal cytotoxic concentration: 11300 nM
Estimate against measurement, compound 3: 1.5-fold (0.18 log units) above, and the stated range covers the measured number.
By their numbers in this assay, from the lowest: compound 2; then compound 3; then compound 1.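

In this assay, among these compounds, hydrogen in place of methyl on an aromatic carbon, ortho to a large group and meta to a 3-fluorophenyl group, gives a 2.2-fold lower number from compound 1 to compound 3 (0.34 log units; beyond the scatter) and so provides the first measured reading at this position. The step shows that this methyl is not a silent substituent on this read-out: losing this one carbon, with no ring, hydrogen-bond donor, hydrogen-bond acceptor or net charge involved, moves the number beyond the scatter, though only modestly, and in the direction of higher toxicity in this test. No measurement at hand accounts for the shift, so it stands as an observation about this single pair and gives no general rule for the series.

The compounds shown carry only hydrogen or methyl at this position, so it remains open whether an ethyl group, a methoxy group or a chlorine atom there would leave the number near that of compound 1 or move it further. Also open, on these data alone, is whether the same replacement on compound 2, which carries the nitrile, would give a step of similar size and direction.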